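The source may report more compounds than this note shows. Statements on the series, on what has been measured and on what is new or still open speak of the compounds shown alone.

Compound 1 `Cc1nn(-c2ncnc3nc[nH]c23)c2c1C(c1ccc(OC(C)C)cc1)CC(=O)N2` is the starting point here. In a functional assay on HEK293 cells for agonist activity at G-protein coupled receptor 39 (Homo sapiens), read by scintillation proximity assay and inositol phosphate accumulation, with a stated time of 75 min (on this read-out higher numbers stand for an effect only at larger amounts of compound and lower numbers for an effect already at smaller amounts), compound 1 gives 2700 nM, the highest of the two numbers available, and the neighbouring value is that of compound 3 `COc1ccc(CCOC2CC(=O)Nc3c2c(C)nn3-c2ncnc3nc[nH]c23)cc1`, which gives 70 nM in this assay, a gap beyond the scatter. Compound 2 `Cc1cc(C)nc(-n2nc(C)c3c2NC(=O)CC3c2ccc(F)cc2F)n1` reaches only the assay limit, > 10000 nM, and this is a limit rather than a number; one of the three values shown sits at the limit of > 10000 nM in this assay, at which 1 of the 3 values shown sits.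

Compound 4 `Cc1nn(-c2ncnc3nc[nH]c23)c2c1C(c1ccc(F)cc1Cl)CC(=O)N2` has not been measured. The change from compound 1 is 2-chloro-4-fluorophenyl in place of 4-isopropoxyphenyl on a saturated ring carbon. Within the data shown here, no pair of measured compounds differs in just one place, so no comparable step exists. The shift away from an ether-bearing aryl group towards a bare halogenated ring is taken here as a move that is expected to cost potency in this assay, though the two measured numbers do not settle it. Compound 4 is therefore expected to fall at about 6000 nM, within 2000 nM to 20000 nM, the expected step being a 2.2-fold higher number from compound 1 to compound 4 (0.35 log units; beyond the scatter), with a fair chance that only a limit is reported.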

Compound 4, half-maximal effective concentration: 280 nM
Compound 4: the middle estimate sits 21-fold (1.33 log units) above what was measured; the measured number lies below the stated range.
By their numbers in this assay, from the lowest: compound 3; then compound 4; then compound 1. At a limit, above all of these: compound 2.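

At this position, on a saturated ring carbon three ring bonds from the ring nitrogen, 2-chloro-4-fluorophenyl in place of 4-isopropoxyphenyl gives a 9.6-fold lower number from compound 1 to compound 4 (0.98 log units; beyond the scatter) in this assay. The position is therefore sensitive to the choice of aryl substituents, and the oxygen of the 4-isopropoxyphenyl group is not required for agonist activity on the shared core. No measurement at hand bears on why the step has this size.

The chlorine and the fluorine enter together, so their separate shares in the step cannot be told apart. As far as these compounds go, how an unsubstituted phenyl, a cyclohexyl group or a phenyl ring bearing a carboxylic acid would read at this carbon remains open.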